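Methanesulfonamido in Place of Cyclohexylcarbonyloxy: Expected Vero Cytotoxicity

The source may hold more compounds than are shown below. What is called first, only, known or untested is meant among the compounds shown, and "the series" means these compounds.

Compound 1 `COc1ccccc1C(=O)OC1CCC(CN2CCN(c3cc(=O)c4cc(C(F)(F)F)cc([N+](=O)[O-])c4s3)CC2)CC1`: > 64 ug/mL
Compound 2 `CC(C)S(=O)(=O)OC1CCC(CN2CCN(c3cc(=O)c4cc(C(F)(F)F)cc([N+](=O)[O-])c4s3)CC2)CC1`: > 64 ug/mL
Compound 3 `O=C(OC1CCC(CN2CCN(c3cc(=O)c4cc(C(F)(F)F)cc([N+](=O)[O-])c4s3)CC2)CC1)C1CCCCC1`: > 64 ug/mL

In an ADME assay on Vero cells (Chlorocebus sabaeus) for cytotoxicity, read by MTT assay, with a stated time of 48 h (on this read-out lower numbers stand for stronger inhibition and higher numbers for weaker inhibition), compound 3 gives > 64 ug/mL, which is a limit of the assay and not a number. Compound 1 likewise stands at a limit, > 64 ug/mL. Compound 2 too stands at a limit, > 64 ug/mL. So (the limit of > 64 ug/mL in this assay, at which 3 of the 3 values shown sit), and the steps a step that the two limits leave unreadable from compound 1 to compound 3, a step that the two limits leave unreadable from compound 2 to compound 3 and a step that the two limits leave unreadable from compound 1 to compound 2 cannot be read. Compound 4 `CS(=O)(=O)NC1CCC(CN2CCN(c3cc(=O)c4cc(C(F)(F)F)cc([N+](=O)[O-])c4s3)CC2)CC1` differs from compound 3 as follows: methanesulfonamido in place of (cyclohexylcarbonyl)oxy on a saturated ring carbon. No readable step bears on this change, so the three values point in no direction. Compound 4 is therefore expected to remain at the same limit, with an estimate of 64 ug/mL (32 ug/mL to 128 ug/mL). The expected step is a number no higher from compound 3 to compound 4 (the limit leaves the size open), none beyond the scatter.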

Compound 4, half-maximal inhibitory concentration: 48.5 ug/mL
Estimate against measurement, compound 4: 1.3-fold (0.12 log units) above, within the range that was stated.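

In this assay, going by these compounds alone, compound 4, with methanesulfonamido on the saturated ring carbon, gives 48.5 ug/mL, the only value here that is a number and not a limit: the limit of > 64 ug/mL in this assay, at which 3 of the 4 values shown sit. This change gives an at least 1.3-fold lower number from compound 3 to compound 4 (0.12 log units; that floor lies within the scatter), an at least 1.3-fold lower number from compound 2 to compound 4 (0.12 log units; that floor lies within the scatter) and an at least 1.3-fold lower number from compound 1 to compound 4 (0.12 log units; that floor lies within the scatter). Each step is only a floor, so no difference beyond the scatter is shown, and the steps among compound 1, compound 2 and compound 3 cannot be read.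

On these data alone, whether a simple amine or a carboxylic acid on this ring carbon would lie beyond the scatter from compound 4 stays open.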